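Removing a Methyl on the Core Nitrogen: Expected Inactivity

This account rests on a few compounds, and the source may have more. Where it says the series, first, only, none or still open, it means among the compounds named here.

Measured compounds:
Compound 1 `Nc1nc(=O)ccn1[C@@H]1O[C@H](COP(=O)(O)OP(=O)(O)O)[C@@H](O)[C@H]1O`: >= 100000 nM
Compound 2 `CNc1nc(=O)ccn1[C@@H]1O[C@H](COP(=O)(O)O)[C@@H](O)[C@H]1O`: > 100000 nM

In an in vitro functional assay on 1321-N1 cells for agonist activity at P2Y purinoceptor 6 (Homo sapiens), read by scintillation proximity assay and inositol phosphate accumulation (a higher number here means that more compound is needed for the effect, a lower number that less compound is needed), compound 1 gives >= 100000 nM, which is a limit of the assay and not a number. In this assay compound 2 gives > 100000 nM, again a limit rather than a number. Among the measured compounds shown here, compound 2 therefore stands at the same boundary as the only other measured compound: it shows no measurable agonist effect at the highest concentration tested, as recorded in the limit of > 100000 nM in this assay, at which 1 of the 2 values shown sits, and (the limit of >= 100000 nM in this assay, at which 1 of the 2 values shown sits).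

Compound 3 `Nc1nc(=O)ccn1[C@@H]1O[C@H](COP(=O)(O)O)[C@@H](O)[C@H]1O` has not yet been measured. It differs from compound 2 by hydrogen in place of methyl on a nitrogen on an aromatic ring. For the measured compounds named here, no measured pair shows what this change does here, and compound 1 and compound 3 share only the fact that both values for compound 1 and compound 2 sit at limits. The expected step is a number no higher from compound 2 to compound 3 (the limit leaves the size open), that is, none beyond the scatter, since compound 2 already sits at a limit. Compound 3 is expected to give 100000 nM, within 30000 nM to 300000 nM, most likely again reported as a limit.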

Compound 3, half-maximal effective concentration: > 100000 nM
Compound 3 was reported as a limit; the forecaster's own chance of this, stated with the estimate: 85%; the middle value sits exactly at the limit.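

In this assay compound 3 gives > 100000 nM, a limit of the assay and not a number. Compound 1 and compound 2 also stand at limits, so the steps from each of them to compound 3 cannot be read. The compounds shown leave open whether either change affects agonist activity at all.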